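The source may hold more compounds than are shown below. What is called first, only, known or untested is meant among the compounds shown, and "the series" means these compounds.

Compound 1 `CO[C@H]1C[C@H](Oc2cc(F)c(F)c(-c3cc(F)c(OCCCC(=O)O)c(F)c3)c2)C1` carries a short acid-bearing chain on one aromatic ring and a methoxycyclobutyl ether on the other. In a functional assay on CHO cells for agonist activity at Free fatty acid receptor 1 (Homo sapiens), read by calcium flux (on this read-out lower numbers stand for an effect already at smaller amounts and higher numbers for an effect only at larger amounts of compound), compound 1 reaches only a limit of the assay, > 100000 nM. Compound 2 `CO[C@H]1C[C@H](Oc2cc(F)c(F)c(-c3cc(F)c(OCCC(C)(C)C(=O)O)c(F)c3)c2)C1` also sits at that limit, giving in this assay > 100000 nM. The step that the two limits leave unreadable from compound 1 to compound 2 therefore cannot be read. Compound 3 `CO[C@H]1C[C@H](Oc2cc(F)c(F)c(-c3cc(F)c(OCCCCCCCC(=O)O)c(F)c3)c2)C1`, with a longer chain, gives in this assay a real number, 3480 nM. The step of an at least 28-fold lower number from compound 1 to compound 3 (1.45 log units; beyond the scatter) shows that lengthening the chain matters, and the step of an at least 28-fold lower number from compound 2 to compound 3 (1.45 log units; beyond the scatter) shows the same. The the limit of > 100000 nM in this assay, at which 2 of the 3 values shown sit, is where two of the three compounds stand.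

Compound 4 `O=C(O)CCCOc1c(F)cc(-c2cc(OC3CCOCC3)cc(F)c2F)cc1F` keeps the short chain of compound 1 and alters only the ether on the other ring: oxan-4-yl in place of 3-methoxycyclobutyl on an oxygen on an aromatic ring. Among the measured compounds shown here, none of the measured steps touches this ring, so none bears directly on the change; the chain that did matter is unchanged. Compound 4 is therefore expected to stay at the limit, with an expected step that the limit leaves unreadable from compound 1 to compound 4. The estimated value of compound 4 is 150000 nM, expected to lie between 40000 nM and 600000 nM.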

Compound 4, half-maximal effective concentration: > 100000 nM
Compound 4 was reported as a limit; the forecaster's own chance of this, stated with the estimate: 70%; the middle value is on the limit's open side.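

Compound 1 and compound 4 both stand only at a limit of this assay, not at a real number, so the step between them cannot be read: the limit of > 100000 nM in this assay, at which 3 of the 4 values shown sit.

The compounds shown leave open whether oxan-4-yl in place of 3-methoxycyclobutyl changes the effect at all.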